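From methyl to ethyl: compound 2 and compound 4

The source may report more compounds than this note shows. Statements on the series, on what has been measured and on what is new or still open speak of the compounds shown alone.

Three fluorinated compounds sharing one core have been measured in a functional assay on 518A2 cells (Homo sapiens) for cytotoxicity, read by MTT assay, with a stated time of 72 h; a lower number here means a stronger inhibitor, a higher number a weaker inhibitor. Compound 1 (`CN1C/C(=C\c2ccccc2F)C(=O)/C(=C/c2ccccc2F)C1`) gives 1800 nM and compound 2 (`CN1C/C(=C\c2cc(F)c(F)cc2F)C(=O)/C(=C/c2cc(F)c(F)cc2F)C1`) gives 1600 nM, two values within the scatter of each other. Compound 3 (`CCN1C/C(=C\c2cc(F)cc(F)c2)C(=O)/C(=C/c2cc(F)cc(F)c2)C1`) gives 3300 nM, a higher number than that of compound 2 and just beyond the scatter. Compound 2 and compound 1 therefore sit together at the low end of these numbers.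

Compound 4 (`CCN1C/C(=C\c2cc(F)c(F)cc2F)C(=O)/C(=C/c2cc(F)c(F)cc2F)C1`) has not yet been measured. It differs from compound 2 by methyl in place of hydrogen on a saturated chain carbon bound to an amine nitrogen in a ring, which turns methyl into ethyl. For the measured compounds named here, no measured pair isolates this change. Compound 3 also carries ethyl but has a different fluorine pattern, so its 3300 nM offers only a loose hint toward a higher number. The expected change in this assay is small, a 1.3-fold higher number from compound 2 to compound 4 (0.10 log units; within the scatter), and may not exceed the scatter. For compound 4 the estimated value is 2000 nM, with an expected range from 900 nM to 4500 nM.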

Compound 4, half-maximal inhibitory concentration: 1500 nM
For compound 4 the middle estimate is 1.3-fold (0.12 log units) above the measured one, and the stated range covers the measured number.
By their numbers in this assay, from the lowest: compounds 4, 2, 1 and 3 (each within the scatter of the next, the first and the last beyond it).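

For the compounds shown here, the step isolates what no earlier pair could: with the fluorine pattern of compound 2 held fixed, methyl in place of hydrogen on a saturated chain carbon bound to an amine nitrogen in a ring gives a 1.1-fold lower number from compound 2 to compound 4 (0.03 log units; within the scatter) in this assay. At this position and with this fluorine pattern, the assay therefore does not tell methyl from ethyl, so the added carbon leaves the number unresolved from that of the parent compound. Nothing available explains why the change has so little effect on the number.

The compounds shown leave open whether the same holds with the other fluorine patterns in the series. They also leave open how a longer chain such as propyl, or a benzyl group or a carboxylic acid at this position, would read in this assay.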